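The compounds below may be only part of what the source reports. "The series", "measured", "known", "first", "only" and "open" are said of these compounds alone.

Of the compounds shown here, three have so far been tested in a functional assay on the whole organism (Abdomen, strain Swiss) with Mus musculus as the target, with a stated time of 30 min; on this read-out higher numbers stand for an effect only at larger amounts of compound and lower numbers for an effect already at smaller amounts. Compound 1 `Cc1ccc(/C=C/C(=O)c2ccc(NC(=S)Nc3ccc(Cl)cc3)cc2)cc1` gives 13.1 umol/kg in this assay, compound 2 `COc1ccc(/C=C/C(=O)c2ccc(NC(=S)Nc3ccc(Cl)cc3)cc2)cc1` gives 10.4 umol/kg, and compound 3 `Cc1ccc(/C=C/C(=O)c2ccc(NC(=O)Nc3ccc(Cl)cc3)cc2)cc1` gives 39.7 umol/kg. Compound 2 has the lowest number of the three, but its gap to compound 1 is within the scatter, so the two cannot be told apart; only the gap to compound 3 is beyond the scatter. Among the compounds with values here, the one single-point step measured so far, a 1.3-fold lower number from compound 1 to compound 2 (0.10 log units; within the scatter), shows that swapping the group on that outer ring did not move the number beyond the scatter.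

Compound 4 `O=C(/C=C/c1ccc(Cl)c(Cl)c1)c1ccc(NC(=S)Nc2ccc(Cl)cc2)cc1` has not yet been measured. Compared with compound 2 it carries 3,4-dichlorophenyl in place of 4-methoxyphenyl on a double-bonded chain carbon bound to a double-bonded chain carbon. The step that bears on this change is a 1.3-fold lower number from compound 1 to compound 2 (0.10 log units; within the scatter), since it also altered the group at the same place and stayed within the scatter. Within the data shown here, no measured step involves a dichlorophenyl, so nothing points to a direction. For compound 4 the expected step is therefore a 1.1-fold higher number from compound 2 to compound 4 (0.02 log units; within the scatter), no move beyond the scatter. Compound 4 is thus estimated at 11 umol/kg, with a range from 5 umol/kg to 25 umol/kg.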

Compound 4, dose for 50% inhibition: 6.15 umol/kg
Estimate against measurement, compound 4: 1.8-fold (0.25 log units) above, within the range that was stated.
By their numbers in this assay, from the lowest: compounds 4, 2 and 1 (each within the scatter of the next, the first and the last beyond it); then compound 3.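

In this assay, the place on the double-bonded chain carbon bound to a double-bonded chain carbon now proves to accept a 3,4-dichlorophenyl, with two chlorine atoms and no hydrogen-bond acceptor, and the step against 4-methoxyphenyl (a 1.7-fold lower number from compound 2 to compound 4 (0.23 log units; within the scatter)) stays within the scatter, so these two groups cannot be ranked. Against 4-methylphenyl the picture differs: the step (a 2.1-fold lower number from compound 1 to compound 4 (0.33 log units; beyond the scatter)) is modest, yet it is the first at this place to pass beyond the scatter, so a change here can shift the dose needed. No measurement on hand offers an explanation for this shift.

All the groups shown at this place are substituted phenyl rings, so how an amine or a carboxylic acid on the ring would read remains open. Also open, going by these compounds, is whether the dichlorophenyl gain would hold in the urea series of compound 3.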